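The source may hold more compounds than are shown below. What is called first, only, known or untested is meant among the compounds shown, and "the series" means these compounds.

Measured so far in a functional assay on the whole organism (stomach) with Rattus norvegicus as the target; a lower number here means that less compound is needed, a higher number that more compound is needed for the effect:
Compound 1 `N=C(S)CCn1nc(-c2ccccc2)ccc1=O`: 87.3 mg/kg
Compound 2 `N=C(S)CCCCn1nc(-c2ccccc2)ccc1=O`: > 100 mg/kg
Compound 3 `N=C(S)CCCCCN1N=C(c2ccccc2)CCC1=O`: 100 mg/kg.

Compound 2 gives only a limit of the assay, not a number: the limit of > 100 mg/kg in this assay, at which 1 of the 3 values shown sits. Compound 1 and compound 2 share a core and differ by a group of 3 heavy atoms (1 carbon, 1 nitrogen, 1 sulfur; no ring) in place of a group of 5 heavy atoms (3 carbon, 1 nitrogen, 1 sulfur; no ring), on a saturated chain carbon, two bonds along the chain from an aromatic nitrogen; the measured step is an at least 1.1-fold lower number from compound 2 to compound 1 (0.05 log units; that floor lies within the scatter). Compound 3 has a different core, and how its core differs from that of compound 2 is not broken down here. In this assay compound 3 gives 100 mg/kg, and that number and the number for compound 1 lie within the scatter of each other.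

Compound 4 `N=C(S)CCCN1N=C(c2ccccc2)CCC1=O` has not yet been tested. It stands to compound 3 as compound 1 stands to compound 2: the change is a group of 3 heavy atoms (1 carbon, 1 nitrogen, 1 sulfur; no ring) in place of a group of 5 heavy atoms (3 carbon, 1 nitrogen, 1 sulfur; no ring), on a saturated chain carbon, three bonds along the chain from an amide-type nitrogen in a ring. The surroundings are not identical, since in the measured pair the group sits two bonds along the chain from an aromatic nitrogen, whereas here it sits three bonds along the chain from an amide-type nitrogen in a ring, so this is the same kind of change rather than the same change. The expectation rests on the measured step of an at least 1.1-fold lower number from compound 2 to compound 1 (0.05 log units; that floor lies within the scatter), whose floor lies within the scatter. Accordingly a small step of about a 1.3-fold lower number from compound 3 to compound 4 (0.12 log units; within the scatter) is expected. For compound 4 in this assay the estimate is 75 mg/kg, with a likely range from 35 mg/kg to 140 mg/kg.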

Compound 4, dose for half-maximal effect: 100 mg/kg
For compound 4 the middle estimate is 1.3-fold (0.12 log units) below the measured one; low and high end bracket the measured number.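

In this assay, putting the group of 3 heavy atoms in place of the group of 5 heavy atoms on the core of compound 3 gives no change at the digits printed from compound 3 to compound 4 (within the scatter). Set beside the earlier step on the other core, this gives no firm reading of whether the change carries over from one core to the other: the same change on two cores in this assay, an at least 1.1-fold lower number (0.05 log units; that floor lies within the scatter) from compound 2 to compound 1 and no change at the digits printed (within the scatter) from compound 3 to compound 4; the limit leaves it open whether they differ. That earlier step may be larger than its printed floor, and it starts from compound 2, which has only a limit of the assay and not a number: the limit of > 100 mg/kg in this assay, at which 1 of the 4 values shown sits.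

The compounds shown leave open whether any change at the end of the chain can move the number in this assay by more than the scatter, as an amine or a carboxylic acid in place of the present end group would test. They also leave open how a still longer chain would read on either core, and a pair of compounds with exact numbers on both cores would be needed before the same change could be compared fairly between them.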